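The source may hold more compounds than are shown below. What is called first, only, known or untested is meant among the compounds shown, and "the series" means these compounds.

Compound 1 `O=S(=O)(c1ccc(F)c(F)c1)c1cnc2cc(F)ccc2c1-c1ccc(Cl)cc1` is the starting point. Within the data shown here, in an ADME assay on microsomes from liver (Homo sapiens) for metabolic stability, tested at 2.5 uM (a higher number here means faster removal of the compound, a lower number slower removal), compound 1 gives 0.01 mL/min, the lowest of the three numbers measured so far. Compound 2 `O=S(=O)(c1cccc(F)c1)c1cnc2cc(F)ccc2c1-c1ccc(Cl)cc1` differs from it only by hydrogen in place of fluoro on an aromatic carbon. In this assay compound 2 gives 0.98 mL/min, which is a 98-fold higher number from compound 1 to compound 2 (1.99 log units; beyond the scatter). Compound 3 `O=S(=O)(c1ccc(F)c(F)c1)c1cnc2c(F)cccc2c1-c1cccc(F)c1` is built on a different core, and the difference between the two cores is not broken down here. In this assay compound 3 gives 1.28 mL/min, a number that sits within the usual scatter of the value of compound 2. Compound 4 `O=S(=O)(c1cccc(F)c1)c1cnc2c(F)cccc2c1-c1cccc(F)c1`, not yet measured, differs from compound 3 by hydrogen in place of fluoro on an aromatic carbon, the same change that was made from compound 1 to compound 2, at a place described in the same words. Since that earlier change brought a 98-fold higher number from compound 1 to compound 2 (1.99 log units; beyond the scatter), a rise is expected again, though smaller, since compound 3 already starts at 1.28 mL/min. The step expected from compound 3 to compound 4 is therefore a 3.1-fold higher number from compound 3 to compound 4 (0.49 log units; beyond the scatter). For compound 4 the estimate in this assay is 4 mL/min, expected to lie between 1.3 mL/min and 15 mL/min.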

Compound 4, intrinsic clearance in a liver preparation (reported as CLH), per the amount of preparation that the assay uses: 1.14 mL/min
Estimate against measurement, compound 4: 3.5-fold (0.55 log units) above; measured number outside the range, below it.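

In this assay, trimming 3,4-difluorophenyl to 3-fluorophenyl on the core of compound 3 gives a 1.1-fold lower number from compound 3 to compound 4 (0.05 log units; within the scatter), so the large rise seen on the core of compound 1 did not carry over. Set side by side, the two results clearly differ: the same change on two cores in this assay, a 98-fold higher number (1.99 log units; beyond the scatter) from compound 1 to compound 2 and a 1.1-fold lower number (0.05 log units; within the scatter) from compound 3 to compound 4, 110-fold (2.04 log units) apart, beyond the scatter of two such steps. Among these compounds, this shows that, in this series, the effect of this change on one core cannot be assumed to hold on another; with only two pairs, however, it does not show which feature of the cores matters, why the steps differ, or how the change would behave on any other core.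

A third core would be needed to show whether the same change follows the first pair, the second, or neither. On these data alone, it also remains open how a methoxy group or a nitrile in place of that fluoro group would behave on each of these two cores.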